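Replacing the outer group of compound 3

A few compounds are considered here, and "the series" means these few. Any claim that something is new, unique, unknown or untested is made for them only; others in the source may bear on it.

In a functional assay on A549 cells (Homo sapiens) for inhibition, read by sulforhodamine B assay (a higher number here means a weaker inhibitor of growth, a lower number a stronger inhibitor of growth), compound 1 `COc1cc(-c2ccc(-c3ccc(-c4nc5cc(C)ccc5[nH]4)cc3)cc2)cc(OC)c1OC` gives < 100 nM, which is a limit.
Compound 2 `FC(F)(F)Oc1ccc(-c2ccc(-c3ccc(-c4nc5ccccc5[nH]4)cc3)cc2)cc1` gives 38000 nM.
Compound 3 `Oc1cccc2[nH]c(-c3ccc(-c4ccc(-c5ccc(OC(F)(F)F)cc5)cc4)cc3)nc12` gives 190 nM.

Of the two exact values in this assay, that of compound 3 is the lower. Compound 4 `COc1ccc(-c2ccc(-c3ccc(-c4nc5c(O)cccc5[nH]4)cc3)cc2)cc1OC` keeps the hydroxy group of compound 3 and carries 3,4-dimethoxyphenyl in place of 4-(trifluoromethoxy)phenyl (3,4-dimethoxyphenyl in place of 4-(trifluoromethoxy)phenyl on an aromatic carbon). Within the data shown here, the only measured step, a 200-fold lower number from compound 2 to compound 3 (2.30 log units; beyond the scatter), was large but concerns the hydroxy group, so it sets no size for this exchange. Compound 1, which also carries methoxy groups, stands at the limit of < 100 nM in this assay, at which 1 of the 3 values shown sits. A small move to a lower number, perhaps none beyond the scatter, is therefore expected. The expected step is a 1.7-fold lower number from compound 3 to compound 4 (0.24 log units; within the scatter). Compound 4 is estimated at 110 nM, within an expected range of 25 nM to 450 nM.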

Compound 4, concentration for 50% growth inhibition: 1310 nM
Estimate against measurement, compound 4: 12-fold (1.08 log units) below; measured number above the stated range.
By their numbers in this assay, from the lowest: compound 3; then compound 4; then compound 2. At a limit, below all of these: compound 1.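

In this assay this position proves sensitive to the group it carries: with the hydroxy group kept, 3,4-dimethoxyphenyl in place of 4-(trifluoromethoxy)phenyl gives a 6.9-fold higher number from compound 3 to compound 4 (0.84 log units; beyond the scatter) and so weakens growth inhibition beyond the scatter. The earlier step concerned the hydroxy group alone, so this is the only size shown for an exchange at this place. Nothing measured here gives a cause for this step.

From the compounds shown here alone, it remains open whether both methoxy groups are needed for this change. Going by these compounds, it is also open how 4-methoxyphenyl, or a phenyl ring carrying an amine or a carboxylic acid, would stand at this place.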